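This account rests on a few compounds, and the source may have more. Where it says the series, first, only, none or still open, it means among the compounds named here.

Measured compounds in this set:
compound 1 `CCCSc1nc2nc(C)cc(N3CC[C@@H](C)[C@@H](N(C)c4ncnc5[nH]ccc45)C3)n2n1`, 67100 nM
compound 2 `Cc1cc(N2CC[C@@H](C)[C@@H](N(C)c3ncnc4[nH]ccc34)C2)n2nc(SCc3ccc(Br)cc3)nc2n1`, 55600 nM
compound 3 `Cc1cc(N2CC[C@@H](C)[C@@H](N(C)c3ncnc4[nH]ccc34)C2)n2nc(SCc3ccc(F)c(Cl)c3)nc2n1`, a limit only

In a toxicity assay on GES1 cells (Homo sapiens) for inhibition, read by MTT assay, with a stated time of 72 h (on this read-out higher numbers stand for weaker inhibition and lower numbers for stronger inhibition), compound 1 gives 67100 nM. Compound 2 gives 55600 nM in this assay. Compound 3 reaches only the limit of this assay, > 100000 nM; it is a limit, not a number (the limit of > 100000 nM in this assay, at which 1 of the 3 values shown sits). Compound 1 thus stands at one of two numbers shown, the other being compound 2, and the step between them is a 1.2-fold lower number from compound 1 to compound 2 (0.08 log units; within the scatter). The further steps are an at least 1.4-fold higher number from compound 1 to compound 3 (0.17 log units; that floor lies within the scatter) and an at least 1.7-fold higher number from compound 2 to compound 3 (0.25 log units; that floor lies within the scatter).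

Compound 4 `Cc1ccc(CSc2nc3nc(C)cc(N4CC[C@@H](C)[C@@H](N(C)c5ncnc6[nH]ccc56)C4)n3n2)cc1` is not yet measured. It differs from compound 1 as follows: 4-methylphenyl in place of ethyl on a saturated chain carbon bound to a sulfur. The comparable steps, 4-bromophenyl and 3-chloro-4-fluorophenyl entering at the same place, moved the number little or ran into the limit. A step of similar size is therefore expected here, with no clear direction beyond the scatter: a 1.1-fold higher number from compound 1 to compound 4 (0.05 log units; within the scatter). Compound 4 is estimated at 75000 nM, in the range 35000 nM to 150000 nM, with a fair chance that only a limit is reported.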

Compound 4, half-maximal inhibitory concentration: 82500 nM
Compound 4: middle estimate off by 1.1-fold (0.04 log units), on the low side; low and high end bracket the measured number.
By their numbers in this assay, from the lowest: compounds 2, 1 and 4 (each within the scatter of the next). At a limit, above all of these: compound 3.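

In this assay, a third phenyl-bearing group, 4-methylphenyl in place of ethyl on a saturated chain carbon bound to a sulfur, again leaves the number within the scatter: a 1.2-fold higher number from compound 1 to compound 4 (0.09 log units; within the scatter). Methyl in place of bromo on an aromatic carbon gives a 1.5-fold higher number from compound 2 to compound 4 (0.17 log units; within the scatter), so a phenyl group without halogen reads the same as the bromo one at this position. The remaining step, an at least 1.2-fold lower number from compound 3 to compound 4 (0.08 log units; that floor lies within the scatter), starts from a limit and sets no order: the limit of > 100000 nM in this assay, at which 1 of the 4 values shown sits.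

From the compounds shown here alone, whether an amine or a carboxylic acid on the phenyl ring, or a longer chain in place of propyl, moves the number beyond the scatter stays open. All the changes shown sit at this one place, so nothing can be read about changes elsewhere on the shared core.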